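The source may hold more compounds than are shown below. What is called first, only, known or untested is meant among the compounds shown, and "the series" means these compounds.

In a functional assay on PANC-1 cells (Homo sapiens) for cytotoxicity, read by WST assay, with a stated time of 24 h (a lower number here means a stronger inhibitor, a higher number a weaker inhibitor), three compounds have been measured. Compound 1 `O=C(CCCCCCCCc1ccc(C(F)(F)F)cc1)N1CCCCC1` gives 54000 nM, and compound 2 `COc1ccc(CCCCCCCCC(=O)N2CCCCC2)cc1` gives 89300 nM. Compound 3 `O=C(CCCCCCCCc1cccc(F)c1)N1CCCCC1` is reported only as a limit of the assay, > 100000 nM.

Compound 4 `O=C(CCCCCCCCc1ccc(F)cc1)N1CCCCC1` carries the same atoms as compound 3, joined differently: 4-fluorophenyl in place of 3-fluorophenyl on a saturated chain carbon, eight bonds along the chain from a carbonyl carbon. Among the compounds with values here, two measured steps bear on this change. One is a 1.7-fold higher number from compound 1 to compound 2 (0.22 log units; within the scatter), and the other is an at least 1.1-fold higher number from compound 2 to compound 3 (0.04 log units; that floor lies within the scatter). Going by these compounds, neither shows a change beyond the scatter, although the second gives only a floor, so its true size remains open. On these steps, no large shift is expected in this assay from moving the fluorine-bearing group, and any change is expected to be modest. A number slightly lower than the limit held by compound 3 seems the likeliest outcome, though compound 4 could also reach that limit. The expected size of the change is an at least 1.1-fold lower number from compound 3 to compound 4 (0.04 log units; that floor lies within the scatter). For compound 4 the estimate is 90000 nM, with an expected range from 50000 nM to 150000 nM.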

Compound 4, half-maximal inhibitory concentration: 99800 nM
The estimate for compound 4 lay 1.1-fold (0.04 log units) below the measured number; measured number inside the range.
By their numbers in this assay, from the lowest: compounds 1, 2 and 4 (each within the scatter of the next). At a limit, above all of these: compound 3.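

In this assay, compound 4 gives a number that can be set against two earlier compounds, so fluoro on an aromatic carbon can now be compared with methoxy (a 1.1-fold higher number from compound 2 to compound 4 (0.05 log units; within the scatter)) and with trifluoromethyl (a 1.8-fold higher number from compound 1 to compound 4 (0.27 log units; within the scatter)). Both steps lie within the scatter, so exchanging these three groups on an aromatic carbon produces no readable difference among compounds 1, 2 and 4. The change from 3-fluorophenyl to 4-fluorophenyl gives a number no higher from compound 3 to compound 4 (the limit leaves the size open). That change cannot itself be sized, because compound 3 stands at a limit of the assay: the limit of > 100000 nM in this assay, at which 1 of the 4 values shown sits.

Going by these compounds, whether moving the fluorine has any real effect therefore remains open. Also open, on these data alone, is whether a carboxylic acid or an amine on the aromatic carbon, or a longer chain in place of the saturated chain, would separate from these compounds beyond the scatter.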